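The source may hold more compounds than are shown below. What is called first, only, known or untested is meant among the compounds shown, and "the series" means these compounds.

Of the compounds shown here, three built on one shared core have so far been tested in a functional assay on cells for antagonist activity at Glucagon receptor (Homo sapiens), read by cAMP accumulation, in the presence of a further agent that is not named here; a lower number here means a stronger inhibitor, a higher number a weaker inhibitor. Compound 1 `CCCC(Oc1ccc(-n2cc(C(F)(F)F)cn2)c(C)c1)c1ccc(C(=O)NCCC(=O)O)cc1` gives 1900 nM. Compound 2 `CCCC(Oc1ccc(-n2cc(Cl)cn2)cc1)c1ccc(C(=O)NCCC(=O)O)cc1` gives 6500 nM, which is the higher of the two plain numbers recorded, and its gap to compound 1 lies beyond the usual scatter of repeated measurements. For compound 3 `CCC(Oc1ccc(-n2cc(C(F)(F)F)cn2)cc1)c1ccc(C(=O)NCCC(=O)O)cc1` this assay reports only a limit, > 22000 nM, and no exact number.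

Compound 4 `CCCC(Oc1ccc(-n2cc3ccccc3n2)cc1)c1ccc(C(=O)NCCC(=O)O)cc1` has not yet been measured. It differs from compound 2 in a single place: 2H-indazol-2-yl in place of 4-chloro-1H-pyrazol-1-yl on an aromatic carbon. For the measured compounds named here, no measured pair among the three compounds shows this same exchange, so the size of the step it brings cannot be read off from what is already known.

The expectation is that the step from compound 2 to compound 4 will be a 1.6-fold lower number from compound 2 to compound 4 (0.21 log units; within the scatter), that is, a modest move toward a lower number, though one that may not reach beyond the scatter. On that basis compound 4 is estimated to give 4000 nM in this assay, with a plausible range from 1000 nM to 16000 nM.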

Compound 4, antagonist equilibrium constant: 2000 nM
Compound 4: the middle estimate sits 2.0-fold (0.30 log units) above what was measured, within the range that was stated.
By their numbers in this assay, from the lowest: compounds 1 and 4 (each within the scatter of the next); then compound 2. At a limit, above all of these: compound 3.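

For the compounds shown here, the exchange of 4-chloro-1H-pyrazol-1-yl for 2H-indazol-2-yl gives, in this assay, a 3.3-fold lower number from compound 2 to compound 4 (0.51 log units; beyond the scatter), and this is the first change at a single place in these compounds whose size can be read. The position, an aromatic carbon para to a large group, therefore accepts a larger entering group: a six-membered aromatic ring of carbon only now comes with the five-membered aromatic ring, and the number falls rather than rises. This one pair cannot separate the effect of the added ring from the loss of the chlorine, as both change in the same step.

On these data alone, compound 3 stands only at a limit, and no step can be read from it: the limit of > 22000 nM in this assay, at which 1 of the 4 values shown sits. Still open is how a nitrile or an amine on the carbon-only ring of the 2H-indazol-2-yl group would read in this assay, and whether a plain pyrazole without the chlorine would keep compound 2's number or move it.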